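Replacing the aryl group of compound 3

This account rests on a few compounds, and the source may have more. Where it says the series, first, only, none or still open, it means among the compounds named here.

Among the compounds with values here, in a functional assay on KB cells (Homo sapiens) for antiproliferative activity, read by sulforhodamine B assay, with a stated time of 3 days (a lower number here means that less compound is needed, a higher number that more compound is needed for the effect), compound 3 `CCC1=C(O)c2c(oc(-c3cccc(OC)c3)cc2=O)C(CC)(CC)C1=O` gives 13.3 uM, the lowest number so far. Compound 1 `CCC1=C(O)c2c(oc(-c3ccc(C)cc3)cc2=O)C(CC)(CC)C1=O` gives 39.2 uM and compound 2 `CCC1=C(O)c2c(oc(-c3cccc(C)c3)cc2=O)C(CC)(CC)C1=O` gives 49.7 uM. Compound 4 `CCC1=C(O)c2c(oc(-c3ccc(C)c(F)c3)cc2=O)C(CC)(CC)C1=O` differs from compound 3 as follows: 3-fluoro-4-methylphenyl in place of 3-methoxyphenyl on an aromatic carbon. This puts 3-fluoro-4-methylphenyl in place of 3-methoxyphenyl on an aromatic carbon. The closest measured step is a 2.9-fold lower number from compound 1 to compound 3 (0.47 log units; beyond the scatter), beyond the scatter, and a 3.7-fold lower number from compound 2 to compound 3 (0.57 log units; beyond the scatter) is also beyond it. By contrast, a 1.3-fold higher number from compound 1 to compound 2 (0.10 log units; within the scatter) stays within the scatter. Within the data shown here, no fluorinated compound has been measured. Leaving the 3-methoxyphenyl is expected to reverse a modest step, and the estimated step is a 2.3-fold higher number from compound 3 to compound 4 (0.35 log units; beyond the scatter). For compound 4 the expected value is 30 uM, with an estimated range of 13 uM to 68 uM.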

Compound 4, concentration for half-maximal effect: 28.1 uM
Compound 4: middle estimate off by 1.1-fold (0.03 log units), on the high side; the range from low to high includes it.
By their numbers in this assay, from the lowest: compound 3; then compounds 4, 1 and 2 (each within the scatter of the next).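

In this assay, within the data shown here, fluoro in place of hydrogen on the aryl group gives a 1.4-fold lower number from compound 1 to compound 4 (0.14 log units; within the scatter), the first reading of fluoro at this position, and 3-fluoro-4-methylphenyl in place of 3-methylphenyl gives a 1.8-fold lower number from compound 2 to compound 4 (0.25 log units; within the scatter). Moving away from 3-methoxyphenyl gives a 2.1-fold higher number from compound 3 to compound 4 (0.32 log units; beyond the scatter), so among these aryl groups only 3-methoxyphenyl stands apart, with compound 3 beyond the scatter of all three others. No available measurement explains these steps.

Open, going by these compounds, is whether ethoxy or an amine in place of the methoxy of compound 3 keeps this lowest number. Also open, on these data alone, is what fluoro added to the 3-methoxyphenyl would do.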